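Hydroxyalkylamino variation on the fluorobenzyl triazolopyrimidine series

The source may report more compounds than this note shows. Statements on the series, on what has been measured and on what is new or still open speak of the compounds shown alone.

Measured compounds in an assay on isolated protein for binding affinity to adenosine receptor A1 (Bos taurus); a lower number here means a stronger inhibitor, a higher number a weaker inhibitor:
- compound 1 `Fc1ccccc1Cn1nnc2c(NC3CCCCC3)nc(-c3ccccc3)nc21`: 1150000 nM
- compound 2 `OC1CCC(Nc2nc(-c3ccccc3)nc3c2nnn3Cc2ccccc2F)CC1`: 1850000 nM
- compound 3 `CC(O)CNc1nc(-c2ccccc2)nc2c1nnn2Cc1ccccc1F`: 4800000 nM

Compound 3 gives the highest number of the three in this assay. From compound 1 to compound 3 the number rose a 4.2-fold higher number from compound 1 to compound 3 (0.62 log units; beyond the scatter), and from compound 2 to compound 3 it rose a 2.6-fold higher number from compound 2 to compound 3 (0.41 log units; beyond the scatter); both steps lie beyond the scatter. Adding a hydroxy to the ring of compound 1 gave a 1.6-fold higher number from compound 1 to compound 2 (0.21 log units; within the scatter), within the scatter.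

Compound 4 `OCCCNc1nc(-c2ccccc2)nc2c1nnn2Cc1ccccc1F` is not yet measured. Against compound 3 the change is 2-hydroxyethyl in place of 1-hydroxyethyl on a saturated chain carbon bound to a nitrogen on an aromatic ring. For the measured compounds named here, none of the measured steps moves a hydroxy along a chain; the nearest comparison is the hydroxy added on the ring in the step from compound 1 to compound 2, which stayed within the scatter. Both amines remain open chains of equal size, so the step in this assay from compound 3 to compound 4 is expected to be small, a 1.2-fold lower number from compound 3 to compound 4 (0.08 log units; within the scatter), with no clear direction. Compound 4 is therefore estimated at 4000000 nM, within 1500000 nM to 12000000 nM.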

Compound 4, inhibition constant: 3700000 nM
Compound 4: the middle estimate sits 1.1-fold (0.03 log units) above what was measured, and the stated range covers the measured number.
By their numbers in this assay, from the lowest: compounds 1, 2, 4 and 3 (each within the scatter of the next, the first and the last beyond it).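

In this assay, moving the hydroxy along the open chain, 2-hydroxypropyl to 3-hydroxypropyl, gives a 1.3-fold lower number from compound 3 to compound 4 (0.11 log units; within the scatter), so this pair does not distinguish the two hydroxy placements. Replacing the 4-hydroxycyclohexyl with 3-hydroxypropyl gives a 2.0-fold higher number from compound 2 to compound 4 (0.30 log units; within the scatter), so this change cannot be separated from the scatter, although the 2-hydroxypropyl step from the same ring compound lay beyond it. Replacing the unsubstituted cyclohexyl with 3-hydroxypropyl gives a 3.2-fold higher number from compound 1 to compound 4 (0.51 log units; beyond the scatter), so both open hydroxy chains now stand beyond the scatter from the cyclohexyl amine.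

From the compounds shown here alone, whether a longer chain such as 4-hydroxybutyl, or a terminal amine or carboxylic acid on the chain, would separate from these values remains open. Nothing available bears on why the steps fall as they do.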